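Swapping the sulfonyl group for a sulfanyl group

A few compounds are considered here, and "the series" means these few. Any claim that something is new, unique, unknown or untested is made for them only; others in the source may bear on it.

Compound 1 `O=C(/C(=C\c1ccccc1OCc1ccccc1)S(=O)(=O)c1ccc(F)cc1)c1ccc(Cl)cc1` in a functional assay on DU-145 cells (Homo sapiens) for inhibition, read by trypan blue exclusion, with a stated time of 96 h (a lower number here means a stronger inhibitor of growth, a higher number a weaker inhibitor of growth), gives 1000 nM
Compound 2 `O=C(O)c1ccc(C(=O)/C(=C\c2ccc(F)c([N+](=O)[O-])c2)SCc2ccc(F)cc2)cc1` in this assay gives 1000 nM

Compound 1 stands level with compound 2 in this assay, so these two values do not separate them. Compound 3 `COc1ccc(S/C(=C/c2ccccc2OCc2ccccc2)C(=O)c2ccc(Cl)cc2)cc1` has not yet been measured. It differs from compound 1 by (4-methoxyphenyl)sulfanyl in place of (4-fluorophenyl)sulfonyl on a double-bonded chain carbon bound to a carbonyl carbon and a double-bonded chain carbon, which places (4-methoxyphenyl)sulfanyl in place of (4-fluorophenyl)sulfonyl on a double-bonded chain carbon bound to a carbonyl carbon and a double-bonded chain carbon. Within the data shown here, no two measured compounds here differ in just one place, so the data offer no guide to the size or direction of such a swap. On these data alone, the expected outcome is therefore no step beyond the usual scatter, and the estimated change is a 1.2-fold higher number from compound 1 to compound 3 (0.08 log units; within the scatter) (a wide range remains open). In this assay the expected value for compound 3 is 1200 nM (estimated range 300 nM to 5000 nM).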

Compound 3, concentration for 50% growth inhibition: 1000 nM
Compound 3: the middle estimate sits 1.2-fold (0.08 log units) above what was measured, and the stated range covers the measured number.
By their numbers in this assay, from the lowest: compounds 1, 2 and 3 (each within the scatter of the next).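

In this assay, among these compounds, the one step that can be read at this position is flat: (4-methoxyphenyl)sulfanyl in place of (4-fluorophenyl)sulfonyl gives no change at the digits printed from compound 1 to compound 3 (within the scatter). On the double-bonded chain carbon bound to a carbonyl carbon and a double-bonded chain carbon, the core of compound 1 can therefore carry either group with no change beyond the scatter. No measurement on hand offers an explanation for this result.

The swap alters the sulfur link and the group on the aromatic ring at once, so the compounds shown cannot say what each change does alone, or whether the two effects offset each other. They also leave open how a group of another kind at this position, such as an amine, would fare.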